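Ester side chains on the shared core: compound 4

The source may hold more compounds than are shown below. What is called first, only, known or untested is meant among the compounds shown, and "the series" means these compounds.

Compound 1 `C=C1C(=O)O[C@@H]2CC(C)=C([C@@H](C)CCCOC(C)=O)[C@@H](OC(=O)CN3CCCC3)[C@H]12` gives 18400 nM in a functional assay on SGC-7901 cells (Homo sapiens) for cytotoxicity, read by sulforhodamine B assay, with a stated time of 72 h; on this read-out lower numbers stand for stronger inhibition and higher numbers for weaker inhibition. Compound 2 `C=C1C(=O)O[C@@H]2CC(C)=C([C@@H](C)CCCOC(C)=O)[C@@H](OC(=O)COc3ccc(C(=O)OCCC)cc3)[C@H]12` gives 27700 nM in this assay, and the two values sit within the scatter of each other. Compound 3 `C=C1C(=O)O[C@@H]2CC(C)=C([C@@H](C)CCCOC(C)=O)[C@@H](OC(=O)COc3ccc([N+](=O)[O-])cc3[N+](=O)[O-])[C@H]12` reaches only a limit of the assay, > 100000 nM in this assay. For the measured compounds named here, the single measured step that bears on the next change is an at least 3.6-fold higher number from compound 2 to compound 3 (0.55 log units; beyond the scatter), an at least modest rise that ends at the limit of > 100000 nM in this assay, at which 1 of the 3 values shown sits. Compound 4 `C=C1C(=O)O[C@@H]2CC(C)=C([C@@H](C)CCCOC(C)=O)[C@@H](OC(=O)COc3cccc4[nH]nnc34)[C@H]12` differs from compound 3 by a group of 9 heavy atoms (6 carbon, 3 nitrogen; one five-membered aromatic ring with 3 hetero atoms, one six-membered aromatic ring of carbon only) in place of a group of 12 heavy atoms (6 carbon, 2 nitrogen, 4 oxygen; one six-membered aromatic ring of carbon only), on an oxygen on a saturated carbon. With the 2,4-dinitrophenyl removed, the number for compound 4 is expected to move back toward the measured values of the series, an expected step of an at least 2.5-fold lower number from compound 3 to compound 4 (0.39 log units; beyond the scatter) in this assay. The estimate for compound 4 is 40000 nM, with a range from 15000 nM to 150000 nM.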

Compound 4, half-maximal inhibitory concentration: 21100 nM
Compound 4: middle estimate off by 1.9-fold (0.28 log units), on the high side, within the range that was stated.
By their numbers in this assay, from the lowest: compounds 1, 4 and 2 (each within the scatter of the next). At a limit, above all of these: compound 3.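

In this assay, a group with one five-membered aromatic ring with 3 hetero atoms on this oxygen gives an at least 4.7-fold lower number from compound 3 to compound 4 (0.67 log units; beyond the scatter), which is a bound only. That limit belongs to compound 3 alone: the limit of > 100000 nM in this assay, at which 1 of the 4 values shown sits.

The new group does not separate from the other side chains, with a 1.3-fold lower number from compound 2 to compound 4 (0.12 log units; within the scatter) and a 1.1-fold higher number from compound 1 to compound 4 (0.06 log units; within the scatter), so among the four compounds only the 2,4-dinitrophenyl of compound 3 stands apart.

Open, from the compounds shown here alone, is whether both nitro groups are needed for that departure, which a 4-nitrophenyl group would test. Also open, going by these compounds, is whether any group at this position leaves the shared band, for example a carboxylic acid on the phenyl ring.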